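Swapping Chloro for Methyl on a Fused Core

The compounds below may be only part of what the source reports. "The series", "measured", "known", "first", "only" and "open" are said of these compounds alone.

Compound 1 `CC(C)Nc1nc(NCc2ccco2)c2cc(Cl)ccc2n1` and compound 2 `CC(C)Nc1nc(NCc2ccco2)c2c(Cl)cccc2n1` hold the same atoms joined differently; the difference between the two cores is not broken down here. In a physicochemical assay for lipophilicity, at pH 3 (on this read-out higher numbers stand for higher lipophilicity and lower numbers for lower lipophilicity), compound 1 gives 2.6 and compound 2 gives 2.62, two numbers within the usual scatter of each other. Compound 3 `Cc1ccc2nc(NC(C)C)nc(NCc3ccco3)c2c1` differs from compound 1 by methyl in place of chloro on an aromatic carbon, and in this assay compound 3 gives 1.55: a large step, a number 1.05 log units lower from compound 1 to compound 3 (beyond the scatter). Compound 4 `Cc1cccc2nc(NC(C)C)nc(NCc3ccco3)c12` differs from compound 2 by methyl in place of chloro on an aromatic carbon. This is the same kind of change, though the place differs: in compound 4 the methyl sits ortho to a fused ring and meta to a fused ring, while in compound 3 it sits meta to a fused ring and para to a fused ring. Among the compounds with values here, a step of similar size is expected, a number 1.02 log units lower from compound 2 to compound 4 (beyond the scatter), because a number 1.05 log units lower from compound 1 to compound 3 (beyond the scatter) is the only measured example of this change. Compound 4 is therefore estimated at 1.6, likely between 1.2 and 2.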

Compound 4, distribution coefficient: 2.44
The estimate for compound 4 lay 0.84 log units below the measured number; the whole stated range lies below it.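

In this assay methyl in place of chloro gives a number 0.18 log units lower from compound 2 to compound 4 (within the scatter) on the core of compound 2, against a number 1.05 log units lower from compound 1 to compound 3 (beyond the scatter) on the core of compound 1, so the size of this swap did not carry from one core to the other. Two pairs show that a single measured step can mislead on a related core, but they give no rule for how the place of the swap governs its size. Nothing available bears on why the two steps differ.

The compounds shown leave open how other groups, such as methoxy or an amine, would read in place of chloro on each core. They also leave open whether the swap on any further core would resemble the step to compound 3 or the step to compound 4.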